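Piperazine amide chain extension and solubility in the nitro series

A few compounds are considered here, and "the series" means these few. Any claim that something is new, unique, unknown or untested is made for them only; others in the source may bear on it.

Compound 3 `CCCCC(=O)N1CCN(c2nc(=O)c3cc(C(F)(F)F)cc([N+](=O)[O-])c3s2)CC1` gives 42.5 ug/mL in a physicochemical assay for solubility, read by HPLC (a higher number here means a more soluble compound, a lower number a less soluble compound), and stands highest of the three numbers. Its nearest neighbour is compound 1 `CCC(=O)N1CCN(c2nc(=O)c3cc(C(F)(F)F)cc([N+](=O)[O-])c3s2)CC1`, which gives 3.29 ug/mL; the step of a 13-fold higher number from compound 1 to compound 3 (1.11 log units; beyond the scatter) is large and beyond the scatter. Furthest below lies compound 2 `CC1COC2(CCN(c3nc(=O)c4cc(C(F)(F)F)cc([N+](=O)[O-])c4s3)CC2)O1`, which gives 0.94 ug/mL; the two values show compound 2 far lower than compound 3.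

Compound 4 `O=C(CC1CCCCC1)N1CCN(c2nc(=O)c3cc(C(F)(F)F)cc([N+](=O)[O-])c3s2)CC1` is not yet measured. It differs from compound 3 by cyclohexyl in place of propyl on a saturated chain carbon bound to a carbonyl carbon. Among the compounds with values here, only one measured step touches the same chain: the step of a 13-fold higher number from compound 1 to compound 3 (1.11 log units; beyond the scatter) lengthened the chain and raised the number strongly. Within the data shown here, the change to compound 4 is of a different kind, a ring entering where a chain leaves, and no measured pair mirrors it, so the prior step is a weak guide. A modest step downward, or none beyond the scatter, is expected for a 2.1-fold lower number from compound 3 to compound 4 (0.33 log units; beyond the scatter). Compound 4 is therefore estimated at 20 ug/mL in this assay, with a range from 4 ug/mL to 90 ug/mL.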

Compound 4, solubility: 0.12 ug/mL
For compound 4 the middle estimate is 170-fold (2.22 log units) above the measured one; the whole stated range lies above it.
By their numbers in this assay, from the lowest: compound 4; then compound 2; then compound 1; then compound 3.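

In this assay the saturated chain carbon bound to a carbonyl carbon does not respond to added carbon in one direction: a 13-fold higher number from compound 1 to compound 3 (1.11 log units; beyond the scatter) came with a longer open chain, while cyclohexyl in place of propyl gives a 350-fold lower number from compound 3 to compound 4 (2.55 log units; beyond the scatter) and cyclohexyl in place of methyl gives a 27-fold lower number from compound 1 to compound 4 (1.44 log units; beyond the scatter). Across compound 1, compound 3 and compound 4, the number therefore does not follow carbon count alone, and the ring-bearing compound 4 falls below both open-chain amides. No measurement bearing on the cause of this fall is available.

As far as these compounds go, whether the fall follows the ring or the size of the group remains open: a longer open chain such as hexyl, or a smaller ring such as cyclopropyl, at this place would separate the two. Also open, from the compounds shown here alone, is how an amine or a carboxylic acid on the cyclohexyl ring would read in this assay.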